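A Third Methoxy Group Added to Compound 3

This account rests on a few compounds, and the source may have more. Where it says the series, first, only, none or still open, it means among the compounds named here.

Compound 1 `C=C(Br)C(=O)Nc1ccc(C(=O)/C=C/c2ccc(OC)cc2)cc1` gives 310 nM in a functional assay on HeLa cells (Homo sapiens) for antiproliferative activity, with a stated time of 48 h; a higher number here means a weaker inhibitor, a lower number a stronger inhibitor. Compound 2 `C=C(Br)C(=O)Nc1ccc(C(=O)/C=C/c2ccc(OC)cc2OC)cc1` carries methoxy in place of hydrogen on an aromatic carbon and gives 1100 nM, so that a 3.5-fold higher number from compound 1 to compound 2 (0.55 log units; beyond the scatter). Compound 3 `COc1ccc(/C=C/C(=O)c2ccc(N)cc2)c(OC)c1` gives 22000 nM, and a 20-fold higher number from compound 2 to compound 3 (1.30 log units; beyond the scatter); the difference between the cores of compound 1 and compound 3 is not broken down here. Compound 4 `COc1ccc(/C=C/C(=O)c2ccc(N)cc2)c(OC)c1OC` is not yet measured and differs from compound 3 by methoxy in place of hydrogen on an aromatic carbon. This is the same kind of change as from compound 1 to compound 2, but the surroundings differ: in compound 2 the new group sits ortho to a large group and meta to a methoxy group, whereas in compound 4 it sits ortho to two methoxy groups and meta to a large group. Because compound 3 gives 22000 nM and the earlier step was a 3.5-fold higher number from compound 1 to compound 2 (0.55 log units; beyond the scatter), compound 4 is expected to show a 2.3-fold higher number from compound 3 to compound 4 (0.36 log units; beyond the scatter) in this assay. The estimate for compound 4 is 50000 nM, likely between 15000 nM and 200000 nM.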

Compound 4, half-maximal inhibitory concentration: 8200 nM
The estimate for compound 4 lay 6.1-fold (0.79 log units) above the measured number; the whole stated range lies above it.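

Adding methoxy in place of hydrogen on an aromatic carbon gave a 2.7-fold lower number from compound 3 to compound 4 (0.43 log units; beyond the scatter), so the change did not keep its direction in this assay when it moved from one core to the other: the same change on two cores in this assay, a 3.5-fold higher number (0.55 log units; beyond the scatter) from compound 1 to compound 2 and a 2.7-fold lower number (0.43 log units; beyond the scatter) from compound 3 to compound 4, 9.5-fold (0.98 log units) apart, beyond the scatter of two such steps In this series, then, a step measured on one of these cores cannot be carried over as a fixed step to the other. This does not show what sets the two steps apart, since the core and the surroundings of the new methoxy group both differ and each step is a single pair. Still open, going by these compounds, is what a third methoxy group would do on a compound keeping (1-bromoethenyl)carbonyl on the nitrogen. Also open, on these data alone, is whether a hydroxy or ethoxy group in that place would follow compound 4.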